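The compounds below may be only part of what the source reports. "The series", "measured", "known", "first", "only" and "open" are said of these compounds alone.

Compound 1, `COc1cccc(-c2ccc(C(=O)N(Cc3cccc(OCCCCCC(=O)O)c3)C(C)C)cc2)c1`, in an ADME assay on BJ cells (Homo sapiens) for cytotoxicity, read by CellTiter-Glo and resazurin assay, with a stated time of 72 h (a higher number here means that more compound is needed for the effect, a lower number that less compound is needed), compound 1 gives > 20900 nM, which is a limit of the assay.
Compound 2, `Cc1nnc(-c2cccc(-c3ccc(C(=O)N(Cc4cccc(OCCCCCC(=O)O)c4)C(C)C)cc3)c2)o1`, in this assay compound 2 gives > 26000 nM, again a limit of the assay.
Compound 3, `CC(C)N(Cc1cccc(OCCCCCC(=O)O)c1)C(=O)c1ccc(-c2cccc(Br)c2)cc1`, in this assay compound 3 gives > 26000 nM, also a limit of the assay.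

Compound 3 therefore stands at a limit, and the two other values shown are limits as well: the limit of > 20900 nM in this assay, at which 1 of the 3 values shown sits, and (the limit of > 26000 nM in this assay, at which 2 of the 3 values shown sit). The three steps among the measured compounds, a step that the two limits leave unreadable from compound 1 to compound 2, a step that the two limits leave unreadable from compound 1 to compound 3 and a step that the two limits leave unreadable from compound 2 to compound 3, are all left unreadable by these limits, so no readable size is known for any change on this aromatic carbon.

Compound 4, `CC(C)N(Cc1cccc(OCCCCCC(=O)O)c1)C(=O)c1ccc(-c2ccc(Cl)c(Cl)c2)cc1`, differs from compound 3 by 3,4-dichlorophenyl in place of 3-bromophenyl on an aromatic carbon. Among the compounds with values here, none of the measured steps bears readably on this change; they show only that the three compounds sit at or past the limits in this assay. The step from compound 3 to compound 4 is therefore expected to be a step that the limit leaves unreadable from compound 3 to compound 4, that is, none beyond the scatter, with compound 4 most likely reported again as a limit. Compound 4 is estimated at 30000 nM, in the range 15000 nM to 100000 nM.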

Compound 4, half-maximal effective concentration: > 26000 nM
Compound 4: only a limit was reported; the forecaster's own chance of this, stated with the estimate: 85%; the middle value is on the limit's open side.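

In this assay compound 4 gives > 26000 nM, again a limit of the assay. No new step can be read, as the limits leave the steps to compound 4 from compound 1, compound 2 and compound 3 all unreadable. The compounds shown leave open whether any change at this aromatic carbon alters the concentration needed for cytotoxicity at all.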